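The source may report more compounds than this note shows. Statements on the series, on what has been measured and on what is new or still open speak of the compounds shown alone.

Measured so far:
- compound 1, `CC1(C)[C@H]2CC[C@]1(C)N(Cc1cn(-c3ccc(Cl)cc3)nn1)C(=O)C2`, 70 nM
- compound 2, `CC1(C)[C@H]2CC[C@]1(C)N(Cc1cn(-c3ccc(F)cc3)nn1)C(=O)C2`, 230 nM

Among the compounds with values here, in a functional assay on A549 cells (Homo sapiens) for inhibition, read by MTT assay, with a stated time of 24 h (a lower number here means a stronger inhibitor, a higher number a weaker inhibitor), compound 2 gives the highest of the two numbers so far; its nearest neighbour is compound 1, and a 3.3-fold higher number from compound 1 to compound 2 (0.52 log units; beyond the scatter), a step beyond the scatter, in which a fluoro replaces a chloro on an aromatic carbon. Compound 3, `CC1(C)[C@H]2CC[C@]1(C)N(Cc1cn(-c3ccc(Br)cc3)nn1)C(=O)C2`, is not yet measured. It differs from compound 2 in one place: bromo in place of fluoro on an aromatic carbon. Within the data shown here, the only measured step that bears on this change is the one from compound 1 to compound 2, which showed that swapping one halogen for another at this position moved the number modestly, with chloro giving the lower number. Bromo is a third halogen at the same place, and no direct comparison with it exists here, so the expectation rests on that single step. Compound 3 is expected to give a lower number than compound 2, by about a 3.8-fold lower number from compound 2 to compound 3 (0.58 log units; beyond the scatter), landing near compound 1. The estimate for compound 3 in this assay is 60 nM, with a range from 20 nM to 180 nM.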

Compound 3, half-maximal inhibitory concentration: 80 nM
Beside the measured number, compound 3's estimate is 1.3-fold (0.12 log units) below it; the range from low to high includes it.
By their numbers in this assay, from the lowest: compounds 1 and 3 (each within the scatter of the next); then compound 2.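

In this assay, the fluoro group can now be compared with two other halogens at the same place on the ring, not just one. Replacing fluoro with bromo gives a 2.9-fold lower number from compound 2 to compound 3 (0.46 log units; beyond the scatter) and so moves the number in the same direction as replacing fluoro with chloro. Replacing chloro with bromo gives a 1.1-fold higher number from compound 1 to compound 3 (0.06 log units; within the scatter) and so cannot be told apart from repeat-to-repeat noise, which means that among these three compounds only fluoro stands apart, with the higher number, while chloro and bromo serve equally well here. Nothing available explains why fluoro differs from the other two halogens.

As far as these compounds go, all three compounds carry a halogen at this place, so it remains open what a group of another kind, such as a methoxy group, a nitrile or a plain hydrogen, would do there. Also open, from the compounds shown here alone, is whether the gap between fluoro and the other two halogens would survive a change elsewhere, for example an ethyl group in place of one of the methyl groups on the shared core.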